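The source may hold more compounds than are shown below. What is called first, only, known or untested is meant among the compounds shown, and "the series" means these compounds.

Compound 1 `CC(=O)OCCOCn1cnc2c(Cl)ncnc21`; in a functional assay on L1210 cells (Mus musculus) for inhibition (a higher number here means a weaker inhibitor, a lower number a stronger inhibitor), compound 1 gives 233 ug/mL.
Compound 2 `CC(=O)OCCOCn1cnc2c(Cl)nc(Cl)nc21`; in this assay compound 2 gives 98 ug/mL.

Among the measured compounds shown here, compound 2 holds the lowest of the two numbers so far in this assay, its only neighbour being compound 1, reached by a 2.4-fold lower number from compound 1 to compound 2 (0.38 log units; beyond the scatter). Compound 3 `CC(=O)OCCOCn1cnc2c(Cl)nc(N)nc21` differs from compound 2 in one place: amino in place of chloro on an aromatic carbon. For the measured compounds named here, no measured step in this set bears directly on this change, since the one step recorded, from compound 1 to compound 2, concerns chloro in place of hydrogen, not amino in place of chloro. That step was modest yet beyond the scatter, which suggests that a single substituent on this core can shift the number noticeably. Without a matching precedent, the direction for compound 3 cannot be read from the data, and only a small step is expected, a 1.5-fold higher number from compound 2 to compound 3 (0.18 log units; within the scatter), well within a wide range. Compound 3 is therefore estimated at 150 ug/mL, between 50 ug/mL and 400 ug/mL.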

Compound 3, concentration for 50% inhibition: > 1000 ug/mL
Compound 3 gave a limit, no number; the forecaster's own chance of this, stated with the estimate: 10%; middle value at least 6.6-fold (0.82 log units) from the limit.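

At the aromatic carbon between two ring nitrogen atoms, the entering group sets the direction of the change, which the earlier pair could not show. In this assay, amino in place of chloro gives an at least 10-fold higher number from compound 2 to compound 3 (1.00 log units; beyond the scatter), and amino in place of hydrogen gives an at least 4.2-fold higher number from compound 1 to compound 3 (0.63 log units; beyond the scatter), whereas chloro in place of hydrogen had lowered the number. The value for compound 3 is a limit, not a number: the limit of > 1000 ug/mL in this assay, at which 1 of the 3 values shown sits.

The compounds shown leave open how far compound 3 lies from compound 2 and compound 1, and why amino and chloro part so sharply at this position. They also leave open whether a methylamino, hydroxyl or fluoro group here would follow chloro or amino.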